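Pyrazolyl enones: difluorophenyl following dimethoxyphenyl

The source may hold more compounds than are shown below. What is called first, only, known or untested is meant among the compounds shown, and "the series" means these compounds.

Compound 1 `COc1cc(-c2cc(/C=C/C(=O)c3ccc(Cl)c(Cl)c3)[nH]n2)cc(OC)c1OC` and compound 2 `COc1ccc(C(=O)/C=C/c2cc(-c3cc(OC)c(OC)c(OC)c3)n[nH]2)cc1OC` share one core and differ only on the carbonyl carbon. In a functional assay on SK-MEL-5 cells (Homo sapiens) for cytotoxicity, read by sulforhodamine B assay, with a stated time of 48 h, tested at 100 uM (on this read-out higher numbers stand for a weaker effect at the one concentration tested and lower numbers for a stronger effect), compound 1 gives -30% and compound 2 gives -92%. The step of a number 62 percentage points lower from compound 1 to compound 2 (beyond the scatter) is the only one measured so far, and compound 2 stands at the lowest of the two numbers, with compound 1 as its nearest neighbour. Compound 3 `COc1cc(-c2cc(/C=C/C(=O)c3ccc(F)c(F)c3)[nH]n2)cc(OC)c1OC` is not yet measured; its change from compound 2 is 3,4-difluorophenyl in place of 3,4-dimethoxyphenyl on a carbonyl carbon. Going by the values given here, this step bears directly on the single measured step, since it removes the 3,4-dimethoxyphenyl that entered from compound 1 to compound 2 and brings in another disubstituted phenyl. A step upward in this assay is therefore expected, but with limited confidence. Among the compounds with values here, a difluorophenyl is not the dichlorophenyl of compound 1, and only one pair is known. The estimated step is a number 47 percentage points higher from compound 2 to compound 3 (beyond the scatter), placing compound 3 at an expected -45%, within a range of -85% to -5%.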

Compound 3, a percentage reported as activity, at one concentration (the size of the read-out at that concentration, not a potency): -88%
Compound 3: the middle estimate sits 43 percentage points above what was measured, and the stated range ends above it.
By their numbers in this assay, from the lowest: compounds 2 and 3 (each within the scatter of the next); then compound 1.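

In this assay, 3,4-difluorophenyl and 3,4-dimethoxyphenyl on the carbonyl carbon are not distinguished, with a number 4 percentage points higher from compound 2 to compound 3 (within the scatter), even though the leaving group carries 2 hydrogen-bond acceptors and the entering group 0. The earlier step therefore did not reflect a simple split between halogen and methoxy substituents: a number 58 percentage points lower from compound 1 to compound 3 (beyond the scatter) shows that exchanging one halogen for another at this position can matter as much as the change to 3,4-dimethoxyphenyl, with compound 1 alone standing apart among the three. No measurement available here explains why the 3,4-dichlorophenyl differs from the other two groups.

Still open, going by these compounds, is whether a phenyl ring bearing an amine or a carboxylic acid on the carbonyl carbon would group with compound 2 and compound 3 or with compound 1. A single high concentration also leaves open whether compound 2 and compound 3 would separate at lower concentrations.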